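The source may hold more compounds than are shown below. What is called first, only, known or untested is meant among the compounds shown, and "the series" means these compounds.

Measured so far:

Compound 1, `Cc1ccc(S(=O)(=O)c2n[nH]c3ccc(N4CCN(C)CC4)cc23)cc1`, gives 100%.
Compound 2, `CN1CCN(c2ccc3[nH]nc(S(=O)(=O)c4ccccc4Cl)c3c2)CC1`, gives 100%.
Compound 3, `COc1cccc(S(=O)(=O)c2n[nH]c3ccc(N4CCN(C)CC4)cc23)c1`, gives 100%.

All three values come from a functional assay on HeLa cells for antagonist activity at 5-hydroxytryptamine receptor 6 (Homo sapiens); on this read-out higher numbers stand for larger maximal responses and lower numbers for smaller maximal responses. On these numbers compound 3 stands level with compounds 1 and 2: the result for compound 3 is within the scatter of both, with compound 1 its nearest and compound 2 its furthest neighbour, and neither gap counts as a real difference.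

The next compound, compound 4, `CN1CCN(c2ccc3[nH]nc(S(=O)(=O)c4c(Cl)cccc4Cl)c3c2)CC1`, differs from compound 3 in one place: 2,6-dichlorophenyl in place of 3-methoxyphenyl on a sulfonyl sulfur. Among the compounds with values here, three measured steps bear on this kind of change. Each of them swaps one aryl group for another on the same sulfonyl sulfur. The step of no change at the digits printed from compound 1 to compound 2 (within the scatter), the step of no change at the digits printed from compound 1 to compound 3 (within the scatter) and the step of no change at the digits printed from compound 2 to compound 3 (within the scatter) were all flat: swapping the aryl group on the sulfonyl sulfur left the maximal response untouched within the scatter. A further swap at the same place is therefore expected to behave alike, and the step to compound 4 is expected to be no change at the digits printed from compound 3 to compound 4 (within the scatter), with no movement beyond the scatter. For compound 4 the estimate is 100%, in the range from 90% to 110%, expected because compound 3 gives 100% and its neighbours did not move.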

Compound 4, largest response reached (reported as Imax), in percent of the reference or control that the assay uses: 100%
Beside the measured number, compound 4's estimate shows no gap at the digits printed; measured number inside the range.
By their numbers in this assay, from the lowest: compounds 1, 2, 3 and 4 (each within the scatter of the next).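

Earlier swaps exchanged one singly substituted aryl group for another, whereas here the aryl group on the sulfonyl sulfur carries two chlorine atoms, and this assay shows no change at the digits printed from compound 3 to compound 4 (within the scatter). Within the data shown here, putting chloro in place of hydrogen on an aromatic carbon is the first change here that adds to an aryl group already present, and it gives no change at the digits printed from compound 2 to compound 4 (within the scatter), while 2,6-dichlorophenyl in place of 4-methylphenyl gives no change at the digits printed from compound 1 to compound 4 (within the scatter). Across these four compounds, then, no aryl group shown on the sulfonyl sulfur moves the maximal response beyond the scatter.

Nothing available gives a reason for this flat result. Going by these compounds, what a carboxylic acid on the aryl group, or a cyclohexyl group in its place, would do remains open, as does any change to the shared core.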